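Dichlorophenyl to 4-hydroxy-3-methoxyphenyl in the cytotoxicity series

This account rests on a few compounds, and the source may have more. Where it says the series, first, only, none or still open, it means among the compounds named here.

Values in a functional assay on A549 cells (Homo sapiens) for cytotoxicity, read by MTT assay, with a stated time of 72 h (a higher number here means a weaker inhibitor, a lower number a stronger inhibitor), for the series:
- compound 1 `COc1ccc(/C=C2\CCC/C(=C\c3ccc(Cl)cc3Cl)C2=O)cc1OC` gives > 20000 nM (a limit)
- compound 2 `COc1ccc(/C=C2\CCC/C(=C\c3cc(Cl)cc(Cl)c3)C2=O)cc1OC` gives 5500 nM
- compound 3 `COc1cc(/C=C2\CCC/C(=C\c3ccc(OC)c(OC)c3)C2=O)ccc1O` is not yet measured

Compound 1 stands at > 20000 nM as a limit of the assay and not a number. Within the data shown here, compound 2, at 5500 nM, holds the only actual number so far. The next change is 4-hydroxy-3-methoxyphenyl in place of 3,5-dichlorophenyl on a double-bonded chain carbon bound to a double-bonded ring carbon, which puts 4-hydroxy-3-methoxyphenyl in place of 3,5-dichlorophenyl on a double-bonded chain carbon bound to a double-bonded ring carbon. Among the measured compounds shown here, one measured step bears on this place, an at least 3.6-fold lower number from compound 1 to compound 2 (0.56 log units; beyond the scatter), a swap between two dichlorophenyl groups. It shows that this assay responds to changes here, but it gives no direction for the entering group. The expected change is a 1.3-fold higher number from compound 2 to compound 3 (0.10 log units; within the scatter), so no clear step beyond the scatter is anticipated. For compound 3 the estimated value is 7000 nM, with an expected range of 2000 nM to 20000 nM in this read-out.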

Compound 3, half-maximal inhibitory concentration: 10300 nM
Estimate against measurement, compound 3: 1.5-fold (0.17 log units) below; measured number inside the range.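

Compound 3 shows that this place tolerates 4-hydroxy-3-methoxyphenyl, a group without chlorine that has a hydrogen-bond donor and acceptors, in place of 3,5-dichlorophenyl, with no clear change in this assay: a 1.9-fold higher number from compound 2 to compound 3 (0.27 log units; within the scatter). Against 2,4-dichlorophenyl the comparison gives an at least 1.9-fold lower number from compound 1 to compound 3 (0.28 log units; that floor lies within the scatter), so no clear gain can be read from it. Compound 1 remains a limit of the assay and not a number: the limit of > 20000 nM in this assay, at which 1 of the 3 values shown sits.

The hydroxy and methoxy groups enter together, so the compounds shown leave open what either one does alone at this place. Also open, going by these compounds, is whether a phenyl ring carrying an amine or a carboxylic acid on a double-bonded chain carbon bound to a double-bonded ring carbon would move the number beyond the scatter.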